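From Naphthalenyl to Methylindolyl: An Untested Step

The compounds below may be only part of what the source reports. "The series", "measured", "known", "first", "only" and "open" are said of these compounds alone.

Of the compounds shown here, three on a shared core have been measured in a functional assay on aorta (strain Wistar) for inhibition, with Thoracic aorta (Rattus norvegicus) as the target; on this read-out higher numbers stand for weaker inhibition and lower numbers for stronger inhibition. Compound 1 `COc1nc(-c2cc3ccccc3o2)cc(-c2cccc3ccccc23)c1C#N` gives 359000 nM. Compound 2 `CCOc1nc(-c2cc3ccccc3o2)cc(-c2cccc3ccccc23)c1C#N` gives 344000 nM in this assay, and compound 3 `COc1ccc(OC)c(-c2cc(-c3cc4ccccc4o3)nc(OC)c2C#N)c1` gives 246000 nM. Compound 2 stands second highest of the three numbers; its nearest neighbour is compound 1, separated by the step of a 1.0-fold lower number from compound 1 to compound 2 (0.02 log units; within the scatter), and compound 3 sits a little lower, still within the scatter, so these three compounds are indistinguishable on this read-out.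

Compound 4 `CCOc1nc(-c2cc3ccccc3o2)cc(-c2cn(C)c3ccccc23)c1C#N` has not yet been measured. It differs from compound 2 in one place: 1-methyl-1H-indol-3-yl in place of naphthalen-1-yl on an aromatic carbon. Going by the values given here, no measured step touches this group; the only known step, a 1.0-fold lower number from compound 1 to compound 2 (0.02 log units; within the scatter), concerns the ethoxy group and was flat. There is thus no direct guide. With every measured number in the same narrow band, the expected step of a 1.1-fold lower number from compound 2 to compound 4 (0.06 log units; within the scatter) is none beyond the scatter. Compound 4 is therefore estimated at 300000 nM, with a range from 100000 nM to 1000000 nM.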

Compound 4, half-maximal inhibitory concentration: 327000 nM
Compound 4: middle estimate off by 1.1-fold (0.04 log units), on the low side; measured number inside the range.
By their numbers in this assay, from the lowest: compounds 3, 4, 2 and 1 (each within the scatter of the next).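

Going by these compounds alone, the only step measured before this one concerned the ethoxy group, whereas compound 4 changes the aromatic carbon opposite the ring nitrogen: in this assay, 1-methyl-1H-indol-3-yl in place of naphthalen-1-yl gives a 1.1-fold lower number from compound 2 to compound 4 (0.02 log units; within the scatter) and so no readable change. This exchange keeps the count of 10 heavy atoms but replaces two six-membered carbon rings with a five-membered ring holding a nitrogen fused to a six-membered carbon ring, and the number stays within the scatter. No other measurement here offers an explanation for this flat result.

As far as these compounds go, all four compounds keep the nitrile and the 1-benzofuran-2-yl group, so it remains open whether any change to the shared core moves the number beyond the scatter. An amine or a carboxylic acid at this position, or a longer chain in place of the ethoxy group, could test that.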